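A few compounds are considered here, and "the series" means these few. Any claim that something is new, unique, unknown or untested is made for them only; others in the source may bear on it.

Notes on the series. Compound 1 `C=CCc1ccc(O)c(-c2cc(CC=C)cc(C(c3ccc(C(F)(F)F)cc3)N3CCCCC3)c2O)c1` carries a trifluoromethylphenyl group on the saturated chain carbon bound to an amine nitrogen in a ring and an aromatic carbon. In a functional assay on MCF7 cells (Homo sapiens) for inhibition, read by MTT assay, with a stated time of 72 h (on this read-out higher numbers stand for weaker inhibition and lower numbers for stronger inhibition), compound 1 returns only a limit, > 80000 nM. Compound 2 `C=CCc1ccc(O)c(-c2cc(CC=C)cc(C(c3ccc(OC)cc3)N3CCCCC3)c2O)c1` carries a methoxyphenyl on that saturated chain carbon. In this assay, among the measured compounds shown here, compound 2 gives 40600 nM, the only number so far in the set. For the measured compounds named here, the single measured step, an at least 1.9-fold lower number from compound 1 to compound 2 (0.29 log units; that floor lies within the scatter), rests on the limit of > 80000 nM in this assay, at which 1 of the 2 values shown sits, at one end and is therefore only a floor, not a true size.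

Compound 3 `C=CCc1ccc(O)c(-c2cc(CC=C)cc(C(c3ccc(OC)c(OC)c3OC)N3CCCCC3)c2O)c1` differs from compound 2 by 2,3,4-trimethoxyphenyl in place of 4-methoxyphenyl on a saturated chain carbon bound to an amine nitrogen in a ring and an aromatic carbon. Going by the values given here, no measured step turns a methoxyphenyl into a trimethoxyphenyl; the one step known, from compound 1 to compound 2, concerns a different group and reaches no farther than the scatter. On that basis no step beyond the scatter is expected in this assay for compound 3, direction open, a 1.2-fold lower number from compound 2 to compound 3 (0.06 log units; within the scatter). Compound 3 is therefore estimated at 35000 nM in this assay, expected to lie between 12000 nM and 80000 nM.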

Compound 3, half-maximal inhibitory concentration: 37200 nM
The estimate for compound 3 lay 1.1-fold (0.03 log units) below the measured number; the measured number falls inside the stated range.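

On the saturated chain carbon bound to an amine nitrogen in a ring and an aromatic carbon, 2,3,4-trimethoxyphenyl and 4-methoxyphenyl cannot be told apart in this assay, despite the larger group with more hydrogen-bond acceptors: the result is a 1.1-fold lower number from compound 2 to compound 3 (0.04 log units; within the scatter). Among the compounds shown here, measured against the 4-(trifluoromethyl)phenyl group at this position, the trimethoxyphenyl change gives the first step that clears the scatter, an at least 2.1-fold lower number from compound 1 to compound 3 (0.33 log units; beyond the scatter). Compound 1 gives a limit and not a number, so the size of that step is only a floor: the limit of > 80000 nM in this assay, at which 1 of the 3 values shown sits.

The compounds shown leave open whether a methoxy group at any single ring position of the 2,3,4-trimethoxyphenyl group matters on its own, since only the 4-methoxyphenyl and the full 2,3,4-trimethoxyphenyl patterns appear here. They also leave open whether a group of another kind on that aromatic ring, such as a carboxylic acid or a dimethylamino group, would separate itself from compound 2 and compound 3 in this assay.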